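Replacing a Methoxybenzyl Ester Group with a Phenoxybutyl Chain

The source may report more compounds than this note shows. Statements on the series, on what has been measured and on what is new or still open speak of the compounds shown alone.

Of the compounds shown here, three built on one shared core have been measured in an assay on isolated protein for binding affinity to Type-2 angiotensin II receptor (Homo sapiens); on this read-out lower numbers stand for stronger inhibition and higher numbers for weaker inhibition. Compound 1 `CCCc1nc(CC)c(C(=O)OCc2ccccc2OC)n1Cc1ccc(-c2ccccc2S(=O)(=O)NC(=O)OCCC(C)C)cc1F` gives 1 nM; compound 2 `CCCc1nc(CC)c(C(=O)OCc2cccc(C(=O)c3ccccc3)c2)n1Cc1ccc(-c2ccccc2S(=O)(=O)NC(=O)OCCC(C)C)cc1F` gives 0.9 nM and compound 3 `CCCc1nc(CC)c(C(=O)OCc2ccccc2Sc2ccccc2)n1Cc1ccc(-c2ccccc2S(=O)(=O)NC(=O)OCCC(C)C)cc1F` gives 2 nM, so all three lie within the scatter of one another. Within the data shown here, the one single-point step among them, a 2.0-fold higher number from compound 1 to compound 3 (0.30 log units; within the scatter), is also within the scatter. Compound 4 `CCCc1nc(CC)c(C(=O)OCCCCOc2ccccc2)n1Cc1ccc(-c2ccccc2S(=O)(=O)NC(=O)OCCC(C)C)cc1F` differs from compound 1 by 3-phenoxypropyl in place of 2-methoxyphenyl on a saturated chain carbon bound to an oxygen next to a carbonyl group. Among the measured compounds shown here, this is a different kind of change from the measured step, so no measured step speaks to it directly; the measured compounds only show that varied ester groups have so far all given similar numbers. A modest weakening is expected, a 3.0-fold higher number from compound 1 to compound 4 (0.48 log units; beyond the scatter). Compound 4 is estimated at 3 nM, with a range from 1 nM to 10 nM.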

Compound 4, half-maximal inhibitory concentration: 2 nM
Beside the measured number, compound 4's estimate is 1.5-fold (0.18 log units) above it, within the range that was stated.
By their numbers in this assay, from the lowest: compounds 2, 1, 3 and 4 (each within the scatter of the next, the first and the last beyond it).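

In this assay, this ester position accepts a 4-phenoxybutyl chain in place of 2-methoxybenzyl, with the number staying within the scatter (a 2.0-fold higher number from compound 1 to compound 4 (0.30 log units; within the scatter)). The earlier compounds shown here all carried substituted benzyl esters, so compound 4 extends the run of similar numbers to an ester of a different kind. No other measurement here explains this result. Still open, going by these compounds, is whether a chain ending in an amine or a carboxylic acid would give a similar number. A longer chain on the phenoxy group's oxygen is equally unresolved.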